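Series note: a further methoxy on the core of compound 1

The compounds below may be only part of what the source reports. "The series", "measured", "known", "first", "only" and "open" are said of these compounds alone.

Among the compounds with values here, compound 1 `COc1cccc(/C=C/C(=O)Nc2cc(C(=O)c3cc(OC)c(OC)c(OC)c3)ccc2OC)c1` gives 5100 nM in a functional assay on COLO 205 cells (Homo sapiens) for cytotoxicity, read by MTT assay, with a stated time of 72 h (on this read-out higher numbers stand for weaker inhibition and lower numbers for stronger inhibition), the lowest of the three numbers measured so far. Compound 3 `COc1ccc(C(=O)c2cc(OC)c(OC)c(OC)c2)cc1NC(=O)/C=C/c1ccc(F)c(F)c1` gives 6020 nM, and the step of a 1.2-fold higher number from compound 1 to compound 3 (0.07 log units; within the scatter) lies within the scatter. Compound 2 `COc1cc(/C=C/C(=O)Nc2cc(C(=O)c3cc(OC)c(OC)c(OC)c3)ccc2OC)ccc1F` gives 11800 nM; the step of a 2.3-fold higher number from compound 1 to compound 2 (0.36 log units; beyond the scatter) lies beyond the scatter, while a 2.0-fold lower number from compound 2 to compound 3 (0.29 log units; within the scatter) lies within it. Compound 4 `COc1cccc(/C=C/C(=O)Nc2cc(C(=O)c3cc(OC)c(OC)c(OC)c3)cc(OC)c2OC)c1` differs from compound 1 by methoxy in place of hydrogen on an aromatic carbon. Within the data shown here, all three measured steps concern the group on the double-bonded chain; none touches the ring that carries the change to compound 4, so no measured step bears on it directly, and the narrow spread across compounds 1 to 3 is the only guide. The expectation for compound 4 is a step of a 1.1-fold higher number from compound 1 to compound 4 (0.03 log units; within the scatter) of no size beyond the scatter. Compound 4 is estimated at 5500 nM, within 2000 nM to 15000 nM.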

Compound 4, half-maximal inhibitory concentration: 10700 nM
Beside the measured number, compound 4's estimate is 1.9-fold (0.29 log units) below it, within the range that was stated.
By their numbers in this assay, from the lowest: compounds 1, 3, 4 and 2 (each within the scatter of the next, the first and the last beyond it).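

In this assay, the only change shown on the core of compound 1 gives a 2.1-fold higher number from compound 1 to compound 4 (0.32 log units; beyond the scatter), so an added methoxy at this place, ortho to a methoxy group and meta to two large groups, registers beyond the scatter, though the step is modest. The earlier compounds shown here varied only the group on the double-bonded chain and said nothing about this position. No measurement shown accounts for the step.

From the compounds shown here alone, only hydrogen and methoxy appear here, so the outcome with a hydroxyl or an amine at this place stays open. Going by these compounds, whether the step would carry over to the 3,4-difluorophenyl of compound 3 also stays open.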